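The compounds below may be only part of what the source reports. "The series", "measured", "known", "first", "only" and "open" are said of these compounds alone.

Compound 1, `COc1cc(-c2cn(-c3ccc(OC(F)(F)F)cc3)nn2)ccc1O`, is the only one of the three measured compounds to give a number at all: in a functional assay on MDA-MB-231 cells (Homo sapiens) for cytotoxicity, read by MTT assay (a lower number here means a stronger inhibitor, a higher number a weaker inhibitor), compound 1 gives 10000 nM. Compound 2, `COc1cc(-c2cn(-c3cc(OC)c(OC)c(OC)c3)nn2)cc(OC)c1OC`, reaches only a limit of the assay, > 10000 nM. Compound 3, `COc1cc(OC)cc(-c2cn(-c3ccc(OC)cc3OC)nn2)c1`, likewise stops at a limit, > 10000 nM. Thus (the limit of > 10000 nM in this assay, at which 2 of the 3 values shown sit). Compound 4, `COc1ccc(-n2cc(-c3ccc(O)c(OC)c3)nn2)cc1`, is not yet measured and differs from compound 1 in one place: methyl in place of trifluoromethyl on an oxygen on an aromatic ring. Among the compounds with values here, no step between two measured compounds is known here, so the size of this change can only be guessed. With compound 1 already sitting at 10000 nM, no step beyond the scatter is expected, though a modest loss would not surprise. Compound 4 is expected to give 10000 nM in this assay, between 4000 nM and 25000 nM, a step of no change at the digits printed from compound 1 to compound 4 (within the scatter).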

Compound 4, half-maximal inhibitory concentration: > 10000 nM
Compound 4 gave a limit, no number; the forecaster's own chance of this, stated with the estimate: 50%; the middle value sits exactly at the limit.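

Within the data shown here, replacing trifluoromethoxy with methoxy on the aromatic ring gives the only comparison here between two compounds that differ in one place, and the change gives a number no lower from compound 1 to compound 4 (the limit leaves the size open) in this assay. Compound 4 stops at a limit, > 10000 nM. The size of the step cannot be read, and most of the set now sits at that same limit: the limit of > 10000 nM in this assay, at which 3 of the 4 values shown sit.

The compounds shown leave open whether another group on this oxygen, such as a longer chain or a chain ending in an amine, would give a lower number.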